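A fluorine moved on the phenyl group of compound 3

The compounds below may be only part of what the source reports. "The series", "measured", "known", "first", "only" and "open" are said of these compounds alone.

- compound 1 `COc1cc(-n2c(-c3ccncc3)cccc2=O)cc(OC)c1OC` gives 1780 nM
- compound 2 `COc1ccc(-n2c(-c3cc(OC)c(OC)c(OC)c3)cccc2=O)cc1O` gives 1220 nM
- compound 3 `COc1cc(-c2cccc(=O)n2-c2cccc(F)c2)cc(OC)c1OC` gives 73 nM

These values come from a functional assay on HepG2 cells (Homo sapiens) for cytotoxicity, read by spectrophotometry, with a stated time of 72 h (a lower number here means a stronger inhibitor, a higher number a weaker inhibitor), and compound 3 holds the lowest number of the three, beyond the scatter from both others. For the measured compounds named here, compound 4 `COc1cc(-c2cccc(=O)n2-c2ccc(F)cc2)cc(OC)c1OC` has the same atoms joined differently, with 4-fluorophenyl in place of 3-fluorophenyl on an aromatic nitrogen as the only change. Going by the values given here, one measured step touches this place: a 17-fold lower number from compound 2 to compound 3 (1.22 log units; beyond the scatter) is large, yet it replaces a different group, so it only loosely guides a change that keeps the same group count. Among the compounds with values here, no 4-fluorophenyl compound has been measured. A small rise is therefore expected, possibly within the scatter, and the estimated step is a 1.4-fold higher number from compound 3 to compound 4 (0.14 log units; within the scatter) in this reading. Compound 4 is estimated at 100 nM with an expected range of 30 nM to 350 nM as its likely span.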

Compound 4, half-maximal inhibitory concentration: > 100000 nM
Compound 4 gave a limit, no number; the forecaster's own chance of this, stated with the estimate: 3%; middle value at least 1000-fold (3.00 log units) away from the limit.
By their numbers in this assay, from the lowest: compound 3; then compounds 2 and 1 (each within the scatter of the next). At a limit, above all of these: compound 4.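

Moving the fluorine on the phenyl group, with no atom gained or lost, gives an at least 1300-fold higher number from compound 3 to compound 4 (3.13 log units; beyond the scatter) in this assay. For the compounds shown here, this shows that the result at this position can depend on where a single fluorine sits, something the earlier compounds, which differ by whole groups, could not show. The 4-fluorophenyl group also compares poorly with 3-hydroxy-4-methoxyphenyl, with an at least 81-fold higher number from compound 2 to compound 4 (1.91 log units; beyond the scatter). The value of compound 4 is a limit, not a number: the limit of > 100000 nM in this assay, at which 1 of the 4 values shown sits.

As far as these compounds go, whether a plain phenyl group, or a chlorine in place of the fluorine, would follow compound 3 or compound 4 remains open.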